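Bromine for Chlorine Within a Second Cytotoxic Core

A few compounds are considered here, and "the series" means these few. Any claim that something is new, unique, unknown or untested is made for them only; others in the source may bear on it.

Compound 1 `COc1cc(/C=C2\CN(C)C/C(=C\c3ccc(Cl)cc3)C2=O)cc(OC)c1OC` gives 7200 nM in a functional assay on THP-1 cells (Homo sapiens) for cytotoxicity, read by MTT assay, with a stated time of 24 h; a lower number here means a stronger inhibitor, a higher number a weaker inhibitor.
Compound 2 `COc1cc(/C=C2\CN(C)C/C(=C\c3ccc(Br)cc3)C2=O)cc(OC)c1OC` gives 5330 nM in this assay.
Compound 3 `CN1C/C(=C\c2ccc(Cl)cc2)C(=O)/C(=C/c2cccc([N+](=O)[O-])c2)C1` gives 7870 nM in this assay.

Compound 1 and compound 2 share one core and differ only in one place: bromo in place of chloro on an aromatic carbon. That change made a 1.4-fold lower number from compound 1 to compound 2 (0.13 log units; within the scatter), so the two compounds cannot be told apart by this measurement. Compound 3 carries a different core; the difference between the two cores is not broken down here. Compound 4 `CN1C/C(=C\c2ccc(Br)cc2)C(=O)/C(=C/c2cccc([N+](=O)[O-])c2)C1` has not been measured. It differs from compound 3 by bromo in place of chloro on an aromatic carbon, the same change seen between compound 1 and compound 2, at a place described in identical words. For compound 4 the step is therefore expected to be small as well, a 1.3-fold lower number from compound 3 to compound 4 (0.12 log units; within the scatter), because a 1.4-fold lower number from compound 1 to compound 2 (0.13 log units; within the scatter) was small. Compound 4 is estimated at 6000 nM, with a likely range from 3000 nM to 12000 nM.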

Compound 4, half-maximal inhibitory concentration: 7690 nM
For compound 4 the middle estimate is 1.3-fold (0.11 log units) below the measured one; the measured number falls inside the stated range.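

Bromo in place of chloro again gives a step too small to separate from the scatter in this assay, at a 1.0-fold lower number from compound 3 to compound 4 (0.01 log units; within the scatter). The change therefore carries over between these two cores as a small step on both, and the two steps do not differ: the same change on two cores in this assay, a 1.4-fold lower number (0.13 log units; within the scatter) from compound 1 to compound 2 and a 1.0-fold lower number (0.01 log units; within the scatter) from compound 3 to compound 4, 1.3-fold (0.12 log units) apart, within the scatter of two such steps. For the compounds shown here, this covers only two pairs on two cores, and steps this small cannot show whether a slight real difference between bromo and chloro exists.

The compounds shown leave open whether fluoro or an amine in the same place would give a larger step. Going by these compounds, whether the swap stays this small on a core carrying a carboxylic acid instead of the nitro group also remains open.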